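The source may report more compounds than this note shows. Statements on the series, on what has been measured and on what is new or still open speak of the compounds shown alone.

Compound 1 `CCCCCCCCCN1CC(=O)N(C)[C@@H](Cc2ccc(-c3cc(OC)c(OC)c(OC)c3)cc2)C1=O` gives 900 nM in a functional assay for agonist activity at follicle-stimulating hormone receptor (Homo sapiens), read by a luciferase reporter; on this read-out higher numbers stand for an effect only at larger amounts of compound and lower numbers for an effect already at smaller amounts. Compound 2 `CCCCCCCN1CC(=O)N(C)[C@@H](Cc2ccc(-c3cc(OC)c(OC)c(OC)c3)cc2)C1=O` gives 2300 nM. Compound 3 `CCCCCCN1C(=O)[C@H](Cc2ccc(-c3cccc(CN(CCCC)C(=O)NC)c3)cc2)N(C)C(=O)[C@@H]1C` gives 7.2 nM.

Compound 4 `CCCCCCCCN1C(=O)[C@H](Cc2ccc(-c3cccc(CN(CCCC)C(=O)NC)c3)cc2)N(C)C(=O)[C@@H]1C` has not yet been measured. It differs from compound 3 by ethyl in place of hydrogen on a saturated chain carbon, six bonds along the chain from an amide-type nitrogen in a ring. Nearly the same change, namely (ethyl in place of hydrogen on a saturated chain carbon, seven bonds along the chain from an amide-type nitrogen in a ring), separates compound 2 from compound 1 and gave a 2.6-fold lower number from compound 2 to compound 1 (0.41 log units; beyond the scatter). The two places are not identical: in one the saturated chain carbon sits seven bonds from the ring nitrogen, in the other six bonds, so this is the same kind of change rather than the same one. The cores of compound 3 and compound 2 also differ, and that difference is not broken down here. Taking the earlier step as a guide, compound 4 is expected to show a 1.8-fold lower number from compound 3 to compound 4 (0.26 log units; within the scatter) in this assay. Compound 4 is therefore estimated at 4 nM, with a likely range from 1.5 nM to 12 nM.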

Compound 4, half-maximal effective concentration: 1.2 nM
Estimate against measurement, compound 4: 3.3-fold (0.52 log units) above; measured number below the stated range.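

In this assay, ethyl in place of hydrogen on the saturated chain carbon, six bonds along the chain from the ring nitrogen, gave a 6.0-fold lower number from compound 3 to compound 4 (0.78 log units; beyond the scatter). Set beside the earlier step, the same kind of change lowers the number on both cores, and the two sizes do not differ beyond the scatter: the same change on two cores in this assay, a 2.6-fold lower number (0.41 log units; beyond the scatter) from compound 2 to compound 1 and a 6.0-fold lower number (0.78 log units; beyond the scatter) from compound 3 to compound 4, 2.3-fold (0.37 log units) apart, within the scatter of two such steps

So the change carried from one core to the other in direction and, within the scatter, in size, but this rests on only two pairs and does not show why the number falls or that it would hold on any further core.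

The compounds shown leave open whether a longer chain would lower the number further on either core. They also leave open what an amine or a carboxylic acid on this chain would do.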